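This account rests on a few compounds, and the source may have more. Where it says the series, first, only, none or still open, it means among the compounds named here.

- Compound 1 `Cc1cc(COc2cc(F)cc(F)c2F)nc(-c2ccccn2)n1` gives 3.4
- Compound 2 `CC1(CS(C)(=O)=O)CN(c2cc(COc3ccc(F)c(F)c3F)nc(-c3ccccn3)n2)C1` gives 2.9

In a physicochemical assay for lipophilicity, at pH 7.4 (a higher number here means a more lipophilic compound, a lower number a more polar compound), compound 2 is the lower of the two, and the gap up to compound 1 lies beyond the scatter. Compound 3 `Fc1ccc(OCc2cc(OCC3(F)COC3)nc(-c3ccccn3)n2)c(F)c1F` has not yet been measured. It carries (3-fluorooxetan-3-yl)methoxy in place of 3-methyl-3-((methylsulfonyl)methyl)azetidin-1-yl on an aromatic carbon. Among the measured compounds shown here, no measured pair shows this change, so the expectation rests only on these two values, with compound 1 at 3.4 as the upper reference. A rise is expected in this assay and the estimated step is a number 0.40 log units higher from compound 2 to compound 3 (beyond the scatter) in size. For compound 3 the estimated value is 3.3 within an expected range from 2.9 to 3.7 overall.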

Compound 3, distribution coefficient: 4
Compound 3: middle estimate off by 0.70 log units, on the low side, outside the stated range (above it).
By their numbers in this assay, from the lowest: compound 2; then compound 1; then compound 3.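

Among the compounds shown here, the change of 3-methyl-3-((methylsulfonyl)methyl)azetidin-1-yl to (3-fluorooxetan-3-yl)methoxy on this aromatic carbon gives the first one-place step at this position, and in this assay it is a number 1.10 log units higher from compound 2 to compound 3 (beyond the scatter), so what stands here strongly affects the read-out. The two groups differ in several counted features, including the number of heavy atoms, sulfur leaving and fluorine entering, and this single pair cannot separate them. No measurement bearing on the cause of this step is available. Still open, going by these compounds, is where an amine or a carboxylic acid on this aromatic carbon would fall, and whether a simple methoxy group would give a similar number.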